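The source may hold more compounds than are shown below. What is called first, only, known or untested is meant among the compounds shown, and "the series" means these compounds.

Compound 1, `CC1(C)[C@H]2CC[C@]1(C)N(Cc1cn(-c3cccc(C#N)c3)nn1)C(=O)C2`: 40 nM
Compound 2, `CC1(C)[C@H]2CC[C@]1(C)N(Cc1cn(-c3cccc(Cl)c3)nn1)C(=O)C2`: 60 nM

Both numbers come from a functional assay on HepG2 cells (Homo sapiens) for inhibition, read by MTT assay, with a stated time of 24 h; on this read-out higher numbers stand for weaker inhibition and lower numbers for stronger inhibition. In this assay, within the data shown here, compound 2 gives 60 nM; the only other measured compound, compound 1, sits at a 1.5-fold higher number from compound 1 to compound 2 (0.18 log units; within the scatter), so the two numbers lie within the usual scatter of each other. Compound 3, `CC1(C)[C@H]2CC[C@]1(C)N(Cc1cn(-c3cccc(Br)c3)nn1)C(=O)C2`, differs from compound 2 by bromo in place of chloro on an aromatic carbon. Among the measured compounds shown here, no measured step replaces chloro by bromo. For the measured compounds named here, the one step known, a 1.5-fold higher number from compound 1 to compound 2 (0.18 log units; within the scatter), replaced cyano by chloro and stayed within the scatter. On that basis no step beyond the scatter is expected here either. The expected step is a 1.1-fold lower number from compound 2 to compound 3 (0.04 log units; within the scatter). For compound 3 the estimate in this assay is 55 nM, within 25 nM to 120 nM.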

Compound 3, half-maximal inhibitory concentration: 20 nM
Beside the measured number, compound 3's estimate is 2.8-fold (0.44 log units) above it, and the stated range ends above it.
By their numbers in this assay, from the lowest: compounds 3, 1 and 2 (each within the scatter of the next, the first and the last beyond it).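

In this assay, going from 3-chlorophenyl to 3-bromophenyl gives a 3.0-fold lower number from compound 2 to compound 3 (0.48 log units; beyond the scatter), so exchanging one halogen atom at this position can shift the number clearly, towards stronger inhibition. By contrast, replacing the nitrile gives a 2.0-fold lower number from compound 1 to compound 3 (0.30 log units; within the scatter), so compound 3 cannot be separated from compound 1. Nothing available explains the halogen step. The compounds shown leave open whether iodo, fluoro or methyl at this position would continue the change from chloro to bromo, and how an amine or a carboxylic acid would behave there.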